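The source may report more compounds than this note shows. Statements on the series, on what has been measured and on what is new or still open speak of the compounds shown alone.

Measured so far:
Compound 1 `O=c1oc2ccccc2cc1C1=NN(c2ccccc2)[C@@H](/C=C/c2ccccc2)C1`: in a functional assay on the whole organism (strain albino) for inhibition, with Rattus norvegicus as the target, read by paw edema, with stated times of 1 h and 4 h, at a dose of 200 mg/kg by the oral route (a higher number here means more inhibition at the dose given (going by the name of the read-out), a lower number less inhibition), compound 1 gives 42.5%.
Compound 2 `O=c1oc2ccccc2cc1C1=NN(c2ccccc2)[C@@H](c2ccc(Cl)cc2Cl)C1`: in this assay compound 2 gives 67.5%.

Among the compounds with values here, compound 2 stands highest of the two numbers; the only measured step is a number 25 percentage points higher from compound 1 to compound 2 (beyond the scatter). Compound 3 `O=c1oc2ccccc2cc1C1=NN(c2ccccc2)[C@@H](c2ccc(O)cc2)C1` differs from compound 2 by 4-hydroxyphenyl in place of 2,4-dichlorophenyl on a saturated ring carbon. Within the data shown here, no measured step exchanges one aryl group for another at this saturated ring carbon, so that one step bears on it only loosely, showing that a change at this position can move the read-out modestly. For compound 3 the expected step is a number 12.5 percentage points lower from compound 2 to compound 3 (beyond the scatter). Compound 3 is estimated at 55%, with a range from 35% to 75%.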

Compound 3, a percentage reported as inhibition, in the whole organism at one dose (the size of the read-out at that dose, not a potency): 34.6%
Compound 3: middle estimate off by 20.4 percentage points, on the high side; the whole stated range lies above it.
By their numbers in this assay, from the lowest: compounds 3 and 1 (each within the scatter of the next); then compound 2.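

Within the data shown here, this is the first exchange of one aryl group for another at the saturated ring carbon, and in this assay it is large: a number 32.9 percentage points lower from compound 2 to compound 3 (beyond the scatter). The read-out therefore depends on which aryl group sits here, and 4-hydroxyphenyl does not keep the level of 2,4-dichlorophenyl. The other step, a number 7.9 percentage points lower from compound 1 to compound 3 (within the scatter), does not separate 4-hydroxyphenyl from 2-phenylethenyl, and nothing at hand explains either step.

The compounds shown leave open whether the loss follows the departing chlorines or the entering hydroxyl, as this step changes both at once. As far as these compounds go, what a 4-methoxyphenyl or 4-aminophenyl group would give at this carbon also remains open.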